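The source may hold more compounds than are shown below. What is called first, only, known or untested is meant among the compounds shown, and "the series" means these compounds.

Working notes on the series. Among the compounds with values here, compound 1 `CNC(=O)CCCCCCCn1nc(-c2ccc3oc(N)nc3c2)c2c(N)ncnc21` gives 3640 nM in a functional assay on HepG2 cells (Homo sapiens) for inhibition, read by MTT assay, with a stated time of 72 h (a lower number here means a stronger inhibitor, a higher number a weaker inhibitor), the only numerical value in hand. Within the data shown here, compound 2 `Nc1ncnc2c1c(-c1cnc3[nH]ccc3c1)nn2CCCC(=O)NO` reaches only the assay limit, > 50000 nM, so the pair yields no measured step. Compound 3 `Nc1nc2cc(-c3nn(CCCCCC(=O)NO)c4ncnc(N)c34)ccc2o1` is the unmeasured analogue of compound 1, differing by hydroxycarbamoyl in place of 2-(methylcarbamoyl)ethyl on a saturated chain carbon, five bonds along the chain from an aromatic nitrogen. Among the measured compounds shown here, with one limit and one number there is no comparable step to lean on; the limit of > 50000 nM in this assay, at which 1 of the 2 values shown sits, belongs to a different core and chain length. From compound 1 to compound 3 the expected step is a 3.0-fold lower number from compound 1 to compound 3 (0.48 log units; beyond the scatter), a modest gain beyond the scatter. Compound 3 is thus estimated at 1200 nM, within 200 nM to 7000 nM.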

Compound 3, half-maximal inhibitory concentration: 1990 nM
Beside the measured number, compound 3's estimate is 1.7-fold (0.22 log units) below it; the measured number falls inside the stated range.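

Hydroxycarbamoyl in place of 2-(methylcarbamoyl)ethyl on a saturated chain carbon, five bonds along the chain from an aromatic nitrogen, gives the first readable step of the series in this assay: a 1.8-fold lower number from compound 1 to compound 3 (0.26 log units; within the scatter). At this position, the two chain ends are therefore not told apart by this read-out. Compound 2 remains a limit and not a number: the limit of > 50000 nM in this assay, at which 1 of the 3 values shown sits.

Chain length and end group change together in this pair, so their contributions stay unseparated. Open, as far as these compounds go, is whether a carboxylic acid at the chain end, or a longer chain carrying hydroxycarbamoyl, would move the number beyond the scatter.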